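Swapping the amide aryl group: from fluoro to methoxy

The source may report more compounds than this note shows. Statements on the series, on what has been measured and on what is new or still open speak of the compounds shown alone.

Compound 1 `COc1cc(C(=O)Nc2ccc(Cl)c(-c3nc4ccccc4[nH]3)c2)cc(OC)c1OC` gives 79.8 nM in a functional assay on Shh Light II cells for inhibition of Sonic hedgehog protein (Mus musculus), read by reporter gene assay, with a stated time of 48 h, in the presence of a further agent that is not named here; on this read-out higher numbers stand for weaker inhibition and lower numbers for stronger inhibition.
Compound 2 `O=C(Nc1ccc(Cl)c(-c2nc3ccccc3[nH]2)c1)c1ccc(F)cc1` gives 251 nM in this assay.
Compound 3 `CCOc1cc(C(=O)Nc2ccc(Cl)c(-c3nc4ccccc4o3)c2)cc(OCC)c1OCC` is reported as "not active" (no number reported) in this assay, with no number given.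

Of the two compounds with a number, compound 2 has the higher value and compound 1 the lower, and the gap between them lies beyond the usual scatter, so compound 1 is the stronger inhibitor of the pair. Compound 3 differs from both in more than one place, and nothing beyond its lack of activity is known.

Compound 4 `COc1ccccc1C(=O)Nc1ccc(Cl)c(-c2nc3ccccc3[nH]2)c1` is a new variant of compound 2: 2-methoxyphenyl in place of 4-fluorophenyl on a carbonyl carbon. Among the measured compounds shown here, no measured pair separates these two groups, so the step cannot be read from the data. For the measured compounds named here, the only guide is that compound 1, whose amide also carries a methoxy-bearing ring, gives 79.8 nM. A small step toward stronger inhibition is therefore expected, a 1.4-fold lower number from compound 2 to compound 4 (0.14 log units; within the scatter), though it may fall within the scatter. Compound 4 is estimated at 180 nM, with a likely range from 60 nM to 550 nM.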

Compound 4, half-maximal inhibitory concentration: 876 nM
Beside the measured number, compound 4's estimate is 4.9-fold (0.69 log units) below it; measured number above the stated range.
By their numbers in this assay, from the lowest: compound 1; then compound 2; then compound 4.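

Placing 2-methoxyphenyl where 4-fluorophenyl stood on the carbonyl carbon gives a 3.5-fold higher number from compound 2 to compound 4 (0.54 log units; beyond the scatter) in this assay, so compound 4 is the weaker inhibitor of this pair. Among the compounds shown here, this is a first measured single change at this place, and it shows that the choice of aryl group there alters inhibition, and that a methoxy-bearing ring is not enough on its own to strengthen it. Nothing measured here explains why inhibition weakens with this swap.

From the compounds shown here alone, whether 4-methoxyphenyl would read like 2-methoxyphenyl or like 4-fluorophenyl stays open, so the effect of the methoxy group cannot be separated from the effect of where it sits on the ring. How a plain phenyl, or a phenyl carrying an amine or a carboxylic acid, would behave at this carbonyl carbon is also unknown.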